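The source may report more compounds than this note shows. Statements on the series, on what has been measured and on what is new or still open speak of the compounds shown alone.

In a functional assay on Jurkat cells (Homo sapiens) for inhibition, read by CCK-8 assay, with a stated time of 48 h (a lower number here means a stronger inhibitor of growth, a higher number a weaker inhibitor of growth), compound 1 (`Cc1ccccc1Nc1nc(Nc2ccc(N3CCN(C(=O)OC(C)(C)C)CC3)cc2)ncc1Cl`) gives 5120 nM. Compound 2 (`CN1CCN(c2ccc(Nc3ncc(Cl)c(NCc4ccccc4)n3)nc2)CC1`) reads > 100000 nM, which is a limit of the assay and not a number. Compound 3 (`COc1ccccc1CNc1nc(Nc2ccc(N3CCN(C)CC3)cn2)ncc1Cl`) differs from compound 2 by methoxy in place of hydrogen on an aromatic carbon, ortho to a large group, which turns benzyl to 2-methoxybenzyl: methoxy in place of hydrogen on an aromatic carbon. Going by the values given here, no measured pair tests this change, so only a modest expected step towards stronger growth inhibition is proposed, an at least 2.0-fold lower number from compound 2 to compound 3 (0.30 log units; that floor lies within the scatter), and the result may again be only a limit. Compound 3 is estimated at 50000 nM, with an expected range of 10000 nM to 100000 nM.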

Compound 3, concentration for 50% growth inhibition: 10800 nM
Compound 3: the middle estimate sits 4.6-fold (0.67 log units) above what was measured; measured number inside the range.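

Turning benzyl to 2-methoxybenzyl, with methoxy ortho to a large group, gives a measurable number in this assay where there was none before: the change brings an at least 9.2-fold lower number from compound 2 to compound 3 (0.96 log units; beyond the scatter). This step has only a lower bound, and its full size cannot be read, as compound 2 reads as a limit and not a number: the limit of > 100000 nM in this assay, at which 1 of the 3 values shown sits.

Still open, on these data alone, is whether another group at this place, such as fluorine, hydroxy or ethoxy, would do the same. Also open, as far as these compounds go, is whether methoxy elsewhere on the benzyl ring would.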